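A few compounds are considered here, and "the series" means these few. Any claim that something is new, unique, unknown or untested is made for them only; others in the source may bear on it.

In a physicochemical assay for lipophilicity (on this read-out higher numbers stand for higher lipophilicity and lower numbers for lower lipophilicity), compound 1 (`CCOC(=O)CC1CCC2(CC1)OOCCCOO2`) gives 2.2, the higher of the two numbers, and compound 2 (`O=C(CC1CCC2(CC1)OOCCCOO2)N1CCOCC1`) gives 1.16. Compound 3 (`c1ccc(CC2CCC3(CC2)OOCCCOO3)cc1`) has phenyl in place of ethoxycarbonyl on a saturated chain carbon bound to a saturated ring carbon. Going by the values given here, one measured step bears on this, and only indirectly, at the same ethoxycarbonyl group: a number 1.04 log units lower from compound 1 to compound 2 (beyond the scatter), a large step. Among the compounds with values here, no compound with phenyl has a measured value yet. A step of similar size in the opposite direction is expected in this assay, estimated as a number 1.40 log units higher from compound 1 to compound 3 (beyond the scatter). For compound 3 the estimated value is 3.6, with an expected range of 3 to 4.2.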

Compound 3, partition coefficient: 3.93
Estimate against measurement, compound 3: 0.33 log units below; the measured number falls inside the stated range.
By their numbers in this assay, from the lowest: compound 2; then compound 1; then compound 3.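

In this assay, phenyl in place of ethoxycarbonyl on a saturated chain carbon bound to a saturated ring carbon gives a number 1.73 log units higher from compound 1 to compound 3 (beyond the scatter), so the read-out at this position also moves upward by a large step. Together with a number 1.04 log units lower from compound 1 to compound 2 (beyond the scatter), this shows that the group at the carbonyl-bearing end can shift the number substantially in either direction from compound 1. No supporting measurement accounts for the size of the new step. Still open, going by these compounds, is where an amine or a carboxylic acid in the same place would fall, and whether a longer chain ending in phenyl would change the number further.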